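The source may hold more compounds than are shown below. What is called first, only, known or untested is meant among the compounds shown, and "the series" means these compounds.

Compound 1 `COc1ccc(NC(=O)COC(=O)/C=C/c2ccc(OCc3ccccc3)c(O)c2)cc1` was tested in a functional assay on PC-3 cells (Homo sapiens) for cytotoxicity, read by MTT assay, with a stated time of 72 h; a higher number here means a weaker inhibitor, a lower number a stronger inhibitor. In this assay compound 1 reaches only a limit, > 200000 nM. For the measured compounds named here, compound 2 `O=C(COC(=O)/C=C/c1ccc(O)c(O)c1)Nc1ccc(Cl)cc1` is the one compound with an actual number in this assay, where compound 2 gives 160000 nM. Compound 3 `COc1ccc(NC(=O)COC(=O)/C=C/c2ccc(O)c(O)c2)cc1` differs from compound 2 in one place: methoxy in place of chloro on an aromatic carbon. Going by the values given here, no measured pair shows what this exchange does, so only a step within the usual scatter, or at most a slight weakening, is expected: the estimated step is a 1.1-fold higher number from compound 2 to compound 3 (0.05 log units; within the scatter). Compound 3 is therefore expected to give about 180000 nM in this assay, in a range from 80000 nM to 400000 nM.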

Compound 3, half-maximal inhibitory concentration: 172000 nM
Compound 3: middle estimate off by 1.0-fold (0.02 log units), on the high side; the range from low to high includes it.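

Exchanging chloro for methoxy on the aromatic carbon gives a 1.1-fold higher number from compound 2 to compound 3 (0.03 log units; within the scatter), so at this position the two groups cannot be told apart in this assay. Hydrogen in place of benzyl on the oxygen can be read only as a floor, an at least 1.1-fold lower number from compound 1 to compound 3 (0.06 log units; that floor lies within the scatter), and the true size of that step stays unknown because compound 1 reaches only a limit: the limit of > 200000 nM in this assay, at which 1 of the 3 values shown sits.

On these data alone, whether an amine or a carboxylic acid on that aromatic carbon would move the number stays open. So does what a methyl on the oxygen would do, as a group smaller than benzyl.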